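Fluorine pattern on the anilide of the shared core

A few compounds are considered here, and "the series" means these few. Any claim that something is new, unique, unknown or untested is made for them only; others in the source may bear on it.

Among the measured compounds shown here, compound 3 `O=C(CN1CCN(c2nnc(Cc3ccccc3)c3ccccc23)CC1)Nc1cccc(F)c1` gives 95000 nM in a functional assay on HT-29 cells (Homo sapiens) for cytotoxicity, read by MTT assay, with a stated time of 72 h (on this read-out lower numbers stand for stronger inhibition and higher numbers for weaker inhibition), the highest of the three numbers measured so far. Compound 2 `O=C(CN1CCN(c2nnc(Cc3ccccc3)c3ccccc23)CC1)Nc1ccc(Br)cc1` gives 60200 nM, and the step of a 1.6-fold higher number from compound 2 to compound 3 (0.20 log units; within the scatter) lies within the scatter, so no order between these two can be read. For the measured compounds named here, compound 1 `O=C(CN1CCN(c2nnc(Cc3ccccc3)c3ccccc23)CC1)Nc1ccc(F)c(F)c1`, which carries a 3,4-difluorophenyl group on the amide-type nitrogen, gives 9510 nM; the step of a 10-fold higher number from compound 1 to compound 3 (1.00 log units; beyond the scatter) is the one single-change step that is clearly beyond the scatter.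

Compound 4 `O=C(CN1CCN(c2nnc(Cc3ccccc3)c3ccccc23)CC1)Nc1c(F)cccc1F` differs from compound 3 by 2,6-difluorophenyl in place of 3-fluorophenyl on an amide-type nitrogen. The measured step that bears on this change is a 10-fold higher number from compound 1 to compound 3 (1.00 log units; beyond the scatter), which shows that the 3,4-difluorophenyl group sits well below the 3-fluorophenyl group on this read-out. Going by the values given here, the 2,6-difluorophenyl group of compound 4 is a different pattern, and no measured pair speaks to it directly, so the transfer is uncertain. On the evidence of compound 1 a lower number is the more likely direction, but of smaller size than the step from compound 1 to compound 3.

Compound 4 is therefore expected at 30000 nM, with a range from 8000 nM to 110000 nM. The expected step is a 3.2-fold lower number from compound 3 to compound 4 (0.50 log units; beyond the scatter).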

Compound 4, half-maximal inhibitory concentration: 19700 nM
Compound 4: middle estimate off by 1.5-fold (0.18 log units), on the high side, and the stated range covers the measured number.
By their numbers in this assay, from the lowest: compound 1; then compound 4; then compounds 2 and 3 (each within the scatter of the next).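

The 2,6-difluorophenyl group on the amide-type nitrogen separates compound 4 from the two higher members of the series in this assay: the steps are a 4.8-fold lower number from compound 3 to compound 4 (0.68 log units; beyond the scatter) and a 3.1-fold lower number from compound 2 to compound 4 (0.49 log units; beyond the scatter), both beyond the scatter. Two fluorines do not settle the outcome on their own, since the two difluorophenyl isomers are themselves separated by a 2.1-fold higher number from compound 1 to compound 4 (0.32 log units; beyond the scatter), a modest step that is still beyond the scatter, so the fluorine pattern counts here as well as the fluorine number, and among these four compounds both difluorophenyl groups give lower numbers than the 3-fluorophenyl and 4-bromophenyl groups. No measured evidence accounts for this order at this position.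

The compounds shown leave open how much of the difference comes from each fluorine, which a plain phenyl, a 2-fluorophenyl and a 4-fluorophenyl group on the same nitrogen would help to separate. Every group shown is a halogenated phenyl, so it also remains open whether a methoxy group, an amine or a carboxylic acid on that ring would fit the same order.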